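Replacing 1-methoxy-1-methylethyl with 2-carboxyethyl on an oxygen

The source may hold more compounds than are shown below. What is called first, only, known or untested is meant among the compounds shown, and "the series" means these compounds.

Among the measured compounds shown here, in a functional assay on FM3A cells (Mus musculus) for cytotoxicity (a higher number here means that more compound is needed for the effect, a lower number that less compound is needed), compound 1 `COOC1(OOC)CCCCCCCCCCC1` gives a half-maximal effective concentration of 1500 nM and compound 2 `COOC1(OOC(C)(C)OC)CCCCCCCCCCC1` gives 7300 nM as the higher of the only two numbers so far. For the measured compounds named here, the one measured step is a 4.9-fold higher number from compound 1 to compound 2 (0.69 log units; beyond the scatter) and lies beyond the scatter, with 1-methoxy-1-methylethyl in place of methyl on an oxygen.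

Compound 3 `COOC1(OOCCC(=O)O)CCCCCCCCCCC1` keeps the shared core, and its change falls on that same oxygen: 2-carboxyethyl in place of 1-methoxy-1-methylethyl on an oxygen is the whole difference from compound 2. Going by the values given here, no measured compound carries the 2-carboxyethyl group, so the data offer no direct guide to its effect. Among the compounds with values here, the only evidence is the move of compound 2 to 7300 nM when its larger group replaced methyl, and a single step makes a weak basis for a trend.

A further modest rise in this assay is therefore expected, an estimated 2.1-fold higher number from compound 2 to compound 3 (0.31 log units; beyond the scatter) with wide uncertainty. Compound 3 is expected at 15000 nM with a likely range from 4000 nM to 60000 nM as the estimate.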

Compound 3, half-maximal effective concentration: 450 nM
The estimate for compound 3 lay 33-fold (1.52 log units) above the measured number, and the stated range ends above it.
By their numbers in this assay, from the lowest: compound 3; then compound 1; then compound 2.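

In this assay, the group on this oxygen can lower the number as well as raise it: 2-carboxyethyl in place of 1-methoxy-1-methylethyl gives a 16-fold lower number from compound 2 to compound 3 (1.21 log units; beyond the scatter), although the group that leaves and the group that enters hold 5 heavy atoms each, so the heavy-atom count alone does not set the number in this pair. Among the compounds shown here, the new group also compares well with the small methyl, with a 3.3-fold lower number from compound 1 to compound 3 (0.52 log units; beyond the scatter), which puts compound 3 lowest of the three and shows that the single earlier step, where a larger group raised the number, was no general rule for this oxygen; compound 3 is the direct exception. Nothing in the available data gives a reason for this reversal.

The three compounds cannot show whether the lower number goes with the carboxylic acid itself or with the unbranched chain that carries it. A plain propyl chain, the methyl ester of the acid, an amine at the chain end or a longer chain ending in the same acid would help separate these two readings.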